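Aryl variation on the triazole of the shared core

A few compounds are considered here, and "the series" means these few. Any claim that something is new, unique, unknown or untested is made for them only; others in the source may bear on it.

Measured compounds:
compound 1 `O=C1O[C@H]([C@@H](O)Cn2cc(-c3cccc(O)c3)nn2)C(OCc2ccccc2)=C1OCc1ccccc1` — 59900 nM
compound 2 `CCCCCc1ccc(-c2cn(C[C@H](O)[C@H]3OC(=O)C(OCc4ccccc4)=C3OCc3ccccc3)nn2)cc1` — 6220 nM
compound 3 `Cc1ccc(-c2cn(C[C@H](O)[C@H]3OC(=O)C(OCc4ccccc4)=C3OCc3ccccc3)nn2)cc1` — 8690 nM

In a functional assay on A549 cells (Homo sapiens) for antiproliferative activity, read by MTT assay, with a stated time of 72 h (a higher number here means a weaker inhibitor, a lower number a stronger inhibitor), compound 3 gives 8690 nM, the second highest of the three numbers; its nearest neighbour is compound 2, and the two lie within the scatter, a 1.4-fold higher number from compound 2 to compound 3 (0.15 log units; within the scatter). The largest gap is to compound 1, a 6.9-fold lower number from compound 1 to compound 3 (0.84 log units; beyond the scatter).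

Compound 4 `O=C1O[C@H]([C@@H](O)Cn2cc(-c3cc(F)cc(F)c3)nn2)C(OCc2ccccc2)=C1OCc1ccccc1` is not yet measured. The change from compound 3 is 3,5-difluorophenyl in place of 4-methylphenyl on an aromatic carbon. Within the data shown here, the steps that bear on this are those that alter the same aryl group. The step of a 6.9-fold lower number from compound 1 to compound 3 (0.84 log units; beyond the scatter) and the step of a 9.6-fold lower number from compound 1 to compound 2 (0.98 log units; beyond the scatter) show that the 3-hydroxyphenyl compound 1 gives a clearly higher number than either aryl without hydrogen-bond donors; between those two, the step of a 1.4-fold higher number from compound 2 to compound 3 (0.15 log units; within the scatter) stays within the scatter. Among the measured compounds shown here, the 3,5-difluorophenyl carries no donor or acceptor either, so no large step in this assay is expected, though a small rise toward compound 1 cannot be excluded.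

The expected step from compound 3 is therefore a 1.3-fold higher number from compound 3 to compound 4 (0.10 log units; within the scatter). For compound 4 the estimate in this assay is 11000 nM, with a range from 4000 nM to 32000 nM.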

Compound 4, half-maximal inhibitory concentration: 41200 nM
Estimate against measurement, compound 4: 3.7-fold (0.57 log units) below; the measured number lies above the stated range.
By their numbers in this assay, from the lowest: compounds 2 and 3 (each within the scatter of the next); then compounds 4 and 1 (each within the scatter of the next).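

In this assay, replacing the aryl group with 3,5-difluorophenyl is not a neutral change: the steps are beyond the scatter against both alkyl-bearing aryl groups (a 4.7-fold higher number from compound 3 to compound 4 (0.68 log units; beyond the scatter); a 6.6-fold higher number from compound 2 to compound 4 (0.82 log units; beyond the scatter)), whereas the step against the 3-hydroxyphenyl stays within it (a 1.5-fold lower number from compound 1 to compound 4 (0.16 log units; within the scatter)). At this aromatic carbon of the five-membered ring, the four compounds therefore fall into two pairs, compounds 2 and 3 with the lower numbers and compounds 1 and 4 with the higher; with 0 hydrogen-bond donors on its 3,5-difluorophenyl, compound 4 shows that a donor on the aryl group does not mark the higher pair. No measurement shown here accounts for this split.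

The compounds shown leave open whether the alkyl groups go with the lower numbers or the fluorine and hydroxyl substituents go with the higher ones. An unsubstituted phenyl, a 4-methoxyphenyl or a 4-aminophenyl at this position would help separate these readings.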